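The source may hold more compounds than are shown below. What is called first, only, known or untested is meant among the compounds shown, and "the series" means these compounds.

Measured compounds in an ADME assay on Raji cells (Homo sapiens) for cytotoxicity, with a stated time of 72 h; on this read-out higher numbers stand for an effect only at larger amounts of compound and lower numbers for an effect already at smaller amounts:

Compound 1 `COc1ccc(NC(=O)Nc2cc(C)nc3ccccc23)cc1OC` gives > 25000 nM, a limit of the assay.
Compound 2 `Cc1cc(NC(=O)Nc2ccccc2C(F)(F)F)c2ccccc2n1` gives > 25000 nM, a limit of the assay.
Compound 3 `COc1cccc(NC(=O)Nc2cc(C)nc3ccccc23)c1` gives > 25000 nM, a limit of the assay.

Compound 1 therefore stands at no number at all in this assay, only at a limit, and the same holds for the other two values shown: the limit of > 25000 nM in this assay, at which 3 of the 3 values shown sit. Going by the values given here, the only measured step that differs in one place, a step that the two limits leave unreadable from compound 1 to compound 3, is unreadable, since both ends of it are limits; its size cannot be taken from these data.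

The next compound, compound 4 `COc1ccc(NC(=O)Nc2cc(C)nc3ccccc23)cc1`, is to be measured in this assay. It differs from compound 1 as follows: hydrogen in place of methoxy on an aromatic carbon. Among the compounds with values here, the step from compound 1 to compound 3 is the one measured step that bears on this change, and it gives no readable size. No direction beyond the scatter can thus be read for the step from compound 1 to compound 4 in this assay; the expected step is a step that the limit leaves unreadable from compound 1 to compound 4, which is here no more than a statement that both ends are expected to lie at the limit.

Compound 4 is accordingly estimated at 40000 nM in this assay, with an expected range from 20000 nM to 100000 nM, most probably reported again as a limit.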

Compound 4, half-maximal effective concentration: > 25000 nM
Compound 4 gave a limit, no number (the forecaster's own chance of this, stated with the estimate: 85%); the middle value is on the limit's open side.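

Compound 1 and compound 4 both give a limit rather than a number in this assay, so no new step can be read for hydrogen in place of methoxy. The compounds shown leave open how far any of them lies from that limit and whether any change to the shared core gives a readable value: the limit of > 25000 nM in this assay, at which 4 of the 4 values shown sit.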